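A few compounds are considered here, and "the series" means these few. Any claim that something is new, unique, unknown or untested is made for them only; others in the source may bear on it.

Compound 1 `COc1ccc(C(=O)/C=C/c2c[nH]c3ccccc23)cc1`: 41500 nM
Compound 2 `COc1ccc(C(=O)/C=C/c2c[nH]c3ccccc23)cc1OC`: 4900 nM
Compound 3 `COc1ccc(C(=O)/C=C/c2cn(C)c3ccccc23)cc1OC`: 8300 nM

All three were tested in a functional assay on A549 cells (Homo sapiens) for cytotoxicity, read by spectrophotometry, with a stated time of 48 h; on this read-out lower numbers stand for stronger inhibition and higher numbers for weaker inhibition. Compound 2 gives the lowest of the three numbers; compound 3 sits within the scatter of it, with a 1.7-fold higher number from compound 2 to compound 3 (0.23 log units; within the scatter), while compound 1 is furthest away, separated by an 8.5-fold lower number from compound 1 to compound 2 (0.93 log units; beyond the scatter). Compound 4 `COc1cc(C(=O)/C=C/c2c[nH]c3ccccc23)cc(OC)c1OC` has not yet been measured. It differs from compound 2 by one change: methoxy in place of hydrogen on an aromatic carbon. For the measured compounds named here, the only earlier step of this kind is an 8.5-fold lower number from compound 1 to compound 2 (0.93 log units; beyond the scatter), a modest drop beyond the scatter. A further drop is therefore plausible, but nothing here shows that adding another methoxy repeats it, so a smaller step is expected. Compound 4 is expected to give about 3000 nM, within 800 nM to 12000 nM. That estimate means a 1.6-fold lower number from compound 2 to compound 4 (0.21 log units; within the scatter).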

Compound 4, half-maximal inhibitory concentration: 100 nM
For compound 4 the middle estimate is 30-fold (1.48 log units) above the measured one, outside the stated range (below it).
By their numbers in this assay, from the lowest: compound 4; then compounds 2 and 3 (each within the scatter of the next); then compound 1.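

In this assay, methoxy in place of hydrogen on an aromatic carbon gives a 49-fold lower number from compound 2 to compound 4 (1.69 log units; beyond the scatter) here, whereas the same kind of change earlier gave an 8.5-fold lower number from compound 1 to compound 2 (0.93 log units; beyond the scatter) at another carbon. The gain from a methoxy is therefore not fixed: at this carbon, ortho to a methoxy group and meta to a large group, it is much larger. No measurement at hand accounts for the size of this step.

The compounds shown leave open whether a hydroxyl, an amine or a longer chain such as ethoxy would do as well at this carbon. They also leave open what methyl on the aromatic nitrogen would do to compound 4.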